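The source may report more compounds than this note shows. Statements on the series, on what has been measured and on what is new or still open speak of the compounds shown alone.

Working notes on the series. Within the data shown here, in a functional assay on a cell-free system (Platelet, plasma, Oryctolagus cuniculus) for inhibition, with a stated time of 5 min, at 37 degrees C (a higher number here means a weaker inhibitor, a lower number a stronger inhibitor), compound 1 (`CCOC(=O)/C=C/c1cc(OC)ccc1OC(=O)c1nc(C)c(C)nc1C`) gives 196000 nM, the higher of the two numbers available so far. Compound 2 (`Cc1nc(C)c(C(=O)Oc2ccc(/C=C/C(=O)O)cc2O)nc1C`) gives 84600 nM, a lower number, and the gap between the two lies beyond the usual scatter. These two compounds differ in more than one place, so their gap does not isolate any single change.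

The next step leads to compound 3 (`CCOC(=O)/C=C/c1cc(Cl)ccc1OC(=O)c1nc(C)c(C)nc1C`), with chloro in place of methoxy on an aromatic carbon, meta to a 2-(ethoxycarbonyl)ethenyl group and para to a large group: chloro in place of methoxy on an aromatic carbon. Among the measured compounds shown here, no measured pair shows this change, so the direction remains open and no shift beyond the scatter is expected in this assay. The estimated step is a 1.2-fold lower number from compound 1 to compound 3 (0.06 log units; within the scatter). For compound 3 the estimated value is 170000 nM, with an expected range of 70000 nM to 400000 nM.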

Compound 3, half-maximal inhibitory concentration: 67100 nM
Beside the measured number, compound 3's estimate is 2.5-fold (0.40 log units) above it; measured number below the stated range.
By their numbers in this assay, from the lowest: compounds 3 and 2 (each within the scatter of the next); then compound 1.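

Chloro in place of methoxy on an aromatic carbon gives a 2.9-fold lower number from compound 1 to compound 3 (0.47 log units; beyond the scatter) in this assay and is the first change in the series that can be read on its own. The position, meta to a 2-(ethoxycarbonyl)ethenyl group and para to a large group, therefore responds to substitution, and the methoxy group is not required for the inhibition seen here. Nothing measured bears on the cause of this modest step.

Only methoxy and chloro are shown at this position, so it remains open whether the step follows from gaining chloro or from losing methoxy, and fluoro, methyl or an amine there would help separate the two. As far as these compounds go, the change also rests on a single pair, so its behaviour with the carboxylic acid side chain of compound 2 remains unknown.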